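A few compounds are considered here, and "the series" means these few. Any claim that something is new, unique, unknown or untested is made for them only; others in the source may bear on it.

Compound 1, `COc1cc2cc(Oc3ccc(NC(=O)Nc4cccc(C(F)(F)F)c4)cc3)c(C)nc2cc1OC`, and compound 2, `COc1cc2cc(Oc3ccc(NC(=O)Nc4ccc(Cl)c(C(F)(F)F)c4)cc3)c(C)nc2cc1OC`, share one core and differ by chloro in place of hydrogen on an aromatic carbon. In a functional assay on MDA-MB-435 cells (Homo sapiens) for inhibition, read by sulforhodamine B assay, with a stated time of 48 h (a lower number here means that less compound is tolerated, a higher number that more compound is tolerated), compound 1 gives only a limit, > 50000 nM. In this assay compound 2 likewise gives only a limit, > 32500 nM. The step that the two limits leave unreadable from compound 1 to compound 2 is not readable; the two values sit at the limit of > 50000 nM in this assay, at which 1 of the 2 values shown sits, and (the limit of > 32500 nM in this assay, at which 1 of the 2 values shown sits). Compound 2 thus stands at a limit, with no measured number to rank it against the other value shown. Compound 3, `COc1cc2cc(Oc3ccc(NC(=O)Nc4ccc(Cl)c(Cl)c4)cc3)c(C)nc2cc1OC`, differs from compound 2 by chloro in place of trifluoromethyl on an aromatic carbon. No measured step bears directly on this change, and the single step shown is unreadable. Compound 3 is therefore expected to remain near the limits. The step is estimated as a step that the limit leaves unreadable from compound 2 to compound 3. In this assay compound 3 is estimated at 40000 nM, within a range from 10000 nM to 100000 nM.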

Compound 3, concentration lethal to 50% of the cells: > 100000 nM
Compound 3 ended at the assay's limit; the forecaster's own chance of this, stated with the estimate: 70%; at least 2.5-fold (0.39 log units) between middle value and limit.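

In this assay compound 3 gives only a limit, as do compound 1 and compound 2, so no step among these three compounds can be read: the limit of > 100000 nM in this assay, at which 1 of the 3 values shown sits. The compounds shown leave open how chloro in place of trifluoromethyl alters the read-out of this measurement.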